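Hydroxymethyl for vinyl on a second core

This account rests on a few compounds, and the source may have more. Where it says the series, first, only, none or still open, it means among the compounds named here.

Compound 1 `C=CC[C@@]12CCN[C@@H]1n1c3nc4ccc(OC)cc4cc3c(=O)c3cccc2c31` gives 7800 nM in a functional assay on MSTO-211H cells (Homo sapiens) for inhibition, read by trypan blue exclusion, with a stated time of 72 h; a higher number here means a weaker inhibitor of growth, a lower number a stronger inhibitor of growth. Compound 2 `COc1ccc2nc3c(cc2c1)c(=O)c1cccc2c1n3[C@H]1NCC[C@@]21CCO` carries the change hydroxymethyl in place of vinyl on a saturated chain carbon bound to a saturated ring carbon and gives 1900 nM in this assay, a step of a 4.1-fold lower number from compound 1 to compound 2 (0.61 log units; beyond the scatter). Compound 3 `C=CC[C@@]12CCN(C(=O)OC(C)(C)C)[C@@H]1n1c3nc4ccc(O)c(CN(C)C)c4cc3c(=O)c3cccc2c31` gives 22800 nM in this assay, the highest of the three numbers. The difference between the core of compound 3 and the core of compound 1 is not broken down here. Compound 4 `CN(C)Cc1c(O)ccc2nc3c(cc12)c(=O)c1cccc2c1n3[C@H]1N(C(=O)OC(C)(C)C)CC[C@@]21CCO`, not yet measured, differs from compound 3 by hydroxymethyl in place of vinyl on a saturated chain carbon bound to a saturated ring carbon, the same change as between compound 1 and compound 2, at the same place. Within the data shown here, only one earlier instance of this change exists, on a different core, so the expected step of a 3.5-fold lower number from compound 3 to compound 4 (0.55 log units; beyond the scatter) is taken from it with a wide margin. Compound 4 is estimated at 6500 nM in this assay, between 2000 nM and 20000 nM.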

Compound 4, concentration for 50% growth inhibition: 20000 nM
Compound 4: the middle estimate sits 3.1-fold (0.49 log units) below what was measured; the range from low to high includes it.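

In this assay, the change from allyl to 2-hydroxyethyl does not carry over at the same size to the second core, giving a 1.1-fold lower number from compound 3 to compound 4 (0.06 log units; within the scatter). The two cores give different steps for the same change: the same change on two cores in this assay, a 4.1-fold lower number (0.61 log units; beyond the scatter) from compound 1 to compound 2 and a 1.1-fold lower number (0.06 log units; within the scatter) from compound 3 to compound 4, 3.6-fold (0.56 log units) apart, beyond the scatter of two such steps. The step on the core of compound 1 therefore cannot be applied as a fixed increment across this series, but two pairs do not show which feature of the cores sets its size, or how the change would behave on any other core.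

As far as these compounds go, it remains open whether the tert-butyl carbamate shared by compound 3 and compound 4 matters for the size of the step. Also open, from the compounds shown here alone, is how an amine or a carboxylic acid in place of the hydroxyl of the 2-hydroxyethyl chain would read on either core.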